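The source may report more compounds than this note shows. Statements on the series, on what has been measured and on what is new or still open speak of the compounds shown alone.

In a toxicity assay on mitochondria for inhibition (on this read-out higher numbers stand for weaker inhibition and lower numbers for stronger inhibition), compound 1 (`O=C(C1=CCCC1)c1cc(Cl)c(O)c(Cl)c1`) gives 10000 nM and compound 2 (`O=C(C1=CCCC1)c1cc(Br)c(O)c(Br)c1`) gives 6600 nM on the same read-out, so compound 2 stands within the scatter of compound 1. Compound 3 (`O=C(c1cc(Br)c(O)c(Br)c1)N1CC=CC1`) differs from compound 2 in one place, on a carbonyl carbon (a group of 5 heavy atoms (4 carbon, 1 nitrogen; one five-membered non-aromatic ring with 1 hetero atom) in place of a group of 5 heavy atoms (5 carbon; one five-membered non-aromatic ring of carbon only), on a carbonyl carbon). Within the data shown here, no measured step covers this change, so only a small move toward weaker inhibition, about the size of the scatter, is expected, with a 1.8-fold higher number from compound 2 to compound 3 (0.26 log units; within the scatter) as the estimated step in this assay for now. The estimated value for compound 3 is 12000 nM with an expected range from 4000 nM to 40000 nM in this measurement.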

Compound 3, half-maximal inhibitory concentration: > 100000 nM
Compound 3 ended at the assay's limit; the forecaster's own chance of this, stated with the estimate: 20%; at least 8.3-fold (0.92 log units) between middle value and limit.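

In this assay, placing the five-membered ring with one nitrogen on the carbonyl carbon in place of cyclopent-1-en-1-yl gives an at least 15-fold higher number from compound 2 to compound 3 (1.18 log units; beyond the scatter), although the count of heavy atoms stays the same. Among these compounds, compounds 1 and 2 share cyclopent-1-en-1-yl, so only this step shows that the read-out responds to a change at this position. Compound 3 gives > 100000 nM, which is a limit and not a number: the limit of > 100000 nM in this assay, at which 1 of the 3 values shown sits.

As far as these compounds go, whether a pyrrolidine, a piperidine or an open-chain diethylamino group on the carbonyl carbon also reaches the limit remains open. From the compounds shown here alone, whether the step holds with chlorine in place of bromine also remains open.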